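This account rests on a few compounds, and the source may have more. Where it says the series, first, only, none or still open, it means among the compounds named here.

Measured in a functional assay (aorta) for inhibition, with Rattus norvegicus as the target; on this read-out higher numbers stand for weaker inhibition and lower numbers for stronger inhibition:
- compound 1 `CCCC/N=C(\S)[C@]1(c2cccnc2)CCCC[S+]1[O-]` gives 8000 nM
- compound 2 `[O-][S+]1CCCC[C@]1(/C(S)=N/c1ccccc1)c1cccnc1` gives > 30000 nM (a limit)

Compound 2 has no number, only a limit, (the limit of > 30000 nM in this assay, at which 1 of the 2 values shown sits).

Compound 3 `O=C(O)CC/N=C(\S)[C@]1(c2cccnc2)CCCC[S+]1[O-]` carries 2-carboxyethyl in place of phenyl on a double-bonded nitrogen. Going by the values given here, the only measured step at this place is an at least 3.7-fold higher number from compound 1 to compound 2 (0.57 log units; beyond the scatter), with phenyl replacing butyl. Like the butyl of compound 1 at 8000 nM, 2-carboxyethyl has no ring, so a modest move toward lower numbers in this assay is expected. As far as these compounds go, the expected change is an at least 1.5-fold lower number from compound 2 to compound 3 (0.17 log units; that floor lies within the scatter), and its true size stays open. The estimate for compound 3 is 20000 nM, with an expected range of 7000 nM to 60000 nM.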

Compound 3, concentration for 90% inhibition: > 30000 nM
Compound 3 ended at the assay's limit (the forecaster's own chance of this, stated with the estimate: 55%); middle value at least 1.5-fold (0.17 log units) away from the limit.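

In this assay, carboxy in place of ethyl on a saturated chain carbon gives an at least 3.7-fold higher number from compound 1 to compound 3 (0.57 log units; beyond the scatter). Loss of the number at the double-bonded nitrogen therefore does not depend on a ring, since 2-carboxyethyl has none and still ends at a limit, as phenyl does. Compound 2 and compound 3 cannot be ordered, and the step between them cannot be read, because both sit at the same limit: the limit of > 30000 nM in this assay, at which 2 of the 3 values shown sit.

As far as these compounds go, how far either compound lies beyond that limit stays open. So does whether a longer alkyl chain or an amine on this nitrogen would give a lower number than butyl.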